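This account rests on a few compounds, and the source may have more. Where it says the series, first, only, none or still open, it means among the compounds named here.

Compound 1 `ClCc1ccc(Cn2cnc3c(Cl)ncnc32)cc1` gives 1940 nM in a functional assay on HOP-62 cells (Homo sapiens) for cytotoxicity, read by sulforhodamine B assay, with a stated time of 48 h; on this read-out higher numbers stand for weaker inhibition of growth and lower numbers for stronger inhibition of growth. Compound 2 `ClCc1cccc(Cn2cnc3ncnc(Cl)c32)c1` gives 2180 nM in this assay; the two have the same atoms joined differently, and the difference between the two cores is not broken down here. Compound 3 `ClCc1ccc(Cn2cnc3c(Cl)nc(Cl)nc32)cc1` gives 2190 nM in this assay. From compound 1 to compound 3 the change is chloro in place of hydrogen on an aromatic carbon, and the step is a 1.1-fold higher number from compound 1 to compound 3 (0.05 log units; within the scatter). Compound 2 and compound 3 lie within the scatter of each other, as do all three measured numbers.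

Compound 4 `ClCc1cccc(Cn2cnc3nc(Cl)nc(Cl)c32)c1` is not yet measured. Relative to compound 2 it carries the same change: chloro in place of hydrogen on an aromatic carbon. Among the compounds with values here, the change occurs twice in the set, and its one measured instance, a 1.1-fold higher number from compound 1 to compound 3 (0.05 log units; within the scatter), is within the scatter. Resting on a 1.1-fold higher number from compound 1 to compound 3 (0.05 log units; within the scatter) alone, a step of about the same size is expected, a 1.1-fold higher number from compound 2 to compound 4 (0.04 log units; within the scatter). Compound 4 is expected to give 2400 nM in this assay, with a range of 1200 nM to 4800 nM. A single measured instance of the change is a thin basis, so the range is kept wide.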

Compound 4, concentration for 50% growth inhibition: 2180 nM
Compound 4: middle estimate off by 1.1-fold (0.04 log units), on the high side; the range from low to high includes it.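

In this assay chloro in place of hydrogen on an aromatic carbon, between two ring nitrogen atoms, gives no change at the digits printed from compound 2 to compound 4 (within the scatter) on this second core. Within this pair of cores the change carries over, with no difference between the two steps beyond the scatter: the same change on two cores in this assay, a 1.1-fold higher number (0.05 log units; within the scatter) from compound 1 to compound 3 and no change at the digits printed (within the scatter) from compound 2 to compound 4, 1.1-fold (0.05 log units) apart, within the scatter of two such steps. Within the data shown here, this shows only that the step stays within the scatter on both cores; since neither step moves the number beyond the scatter, it does not show whether a change with a real effect would transfer from one core to the other, nor does it extend to any core outside this pair.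

The compounds shown carry only hydrogen or chloro at this ring carbon, so the effect of an amine or a methoxy group there remains open. Also open, from the compounds shown here alone, is whether the chloromethyl group could give way to a hydroxymethyl group or a carboxylic acid on either core and leave the growth-inhibition number where it stands.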